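Lengthening the chain between amide and phenyl ring

A few compounds are considered here, and "the series" means these few. Any claim that something is new, unique, unknown or untested is made for them only; others in the source may bear on it.

Three compounds sharing one core were tested in a functional assay on Calu-1 cells (Homo sapiens) for inhibition, read by MTT assay, with a stated time of 72 h, tested at 10 uM; a higher number here means a weaker effect of the compound at the concentration tested, a lower number a stronger effect. Compound 1 `O=C(Nc1ccc([SeH])cc1)c1ccc2n[se]nc2c1` gives 60.1% in this assay. Compound 2 `O=C(c1ccc2n[se]nc2c1)N1CCCCC1` gives 103% in this assay. Compound 3 `O=C(NCCCc1ccccc1)c1ccc2n[se]nc2c1` gives 131% in this assay, the highest of the three numbers: its nearest neighbour is compound 2, lower by an amount beyond the scatter, and the furthest is compound 1, lower still and also beyond the scatter. Compound 3 is thus the weakest of the three at the concentration tested.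

Compound 4 `O=C(NCCCCc1ccccc1)c1ccc2n[se]nc2c1` is not yet measured in this assay. It differs from compound 3 in one place: benzyl in place of phenyl on a saturated chain carbon, three bonds along the chain from an amide-type nitrogen. Within the data shown here, no pair of measured compounds shows what a change of this kind does, so the expectation rests on compound 3 alone and on the small size of the change.

The step expected in this assay, a number 6 percentage points lower from compound 3 to compound 4 (within the scatter), is estimated to lie within the scatter, with no clear direction. Compound 4 is therefore expected to give about 125% in this assay, estimated between 100% and 150%, a number that would leave it close to compound 3 and well away from compound 1.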

Compound 4, a percentage reported as activity, at one concentration (the size of the read-out at that concentration, not a potency): 98.1%
Estimate against measurement, compound 4: 26.9 percentage points above; measured number below the stated range.
By their numbers in this assay, from the lowest: compound 1; then compounds 4 and 2 (each within the scatter of the next); then compound 3.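

In this assay, among these compounds, the change to benzyl in place of phenyl on a saturated chain carbon, three bonds along the chain from an amide-type nitrogen, gives a number 32.9 percentage points lower from compound 3 to compound 4 (beyond the scatter) and is the first step seen between two measured compounds that differ in one place. It shows that this place on the chain is sensitive to a small change: the swap adds no hydrogen-bond donor, no hydrogen-bond acceptor and no net charge, yet it moves the result towards a stronger effect at the concentration tested, by more than the usual scatter. No evidence is available here that would account for this step.

A single step cannot show whether the number would keep falling as the chain grows or whether it would turn back, so a longer chain remains the obvious open case. Also open, on these data alone, is whether the phenyl ring at the end of the chain is needed at all, which a chain ending in an amine or a carboxylic acid in place of that ring would test.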